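The source may report more compounds than this note shows. Statements on the series, on what has been measured and on what is new or still open speak of the compounds shown alone.

Compound 1 `COc1ccc(C[C@@H](O)/C=C/C=C/C(=O)NCc2ccc(Cl)cc2)cc1OC` gives 16500 nM
Compound 2 `CCN1CCN(C(=O)/C=C/C=C/[C@H](O)Cc2ccc(OC)c(OC)c2)CC1` gives 15700 nM

In a functional assay on A549 cells (Homo sapiens) for antiproliferative activity, read by sulforhodamine B assay, with a stated time of 48 h (on this read-out higher numbers stand for weaker inhibition and lower numbers for stronger inhibition), compound 2 gives 15700 nM and lies within the scatter of compound 1. Compound 3 `COc1ccc(C[C@@H](O)/C=C/C=C/C(=O)N2CCCC2)cc1OC` has not yet been measured. It differs from compound 2 by pyrrolidin-1-yl in place of 4-ethylpiperazin-1-yl on a carbonyl carbon on a carbonyl carbon, with pyrrolidin-1-yl in place of 4-ethylpiperazin-1-yl. Within the data shown here, only one measured step bears on this carbonyl carbon, a 1.1-fold lower number from compound 1 to compound 2 (0.02 log units; within the scatter) and it stays within the scatter, with 4-ethylpiperazin-1-yl in place of (4-chlorobenzyl)amino. Among the measured compounds shown here, no measured compound carries pyrrolidin-1-yl, so this single step is thin evidence. On this basis no step beyond the scatter is expected in this assay for the new change, in either direction. The estimate amounts to a 1.0-fold higher number from compound 2 to compound 3 (0.01 log units; within the scatter) and so stays within the scatter. For compound 3 the estimated value is 16000 nM and the expected range runs between 7000 nM and 35000 nM on that estimate.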

Compound 3, half-maximal inhibitory concentration: 24400 nM
Compound 3: the middle estimate sits 1.5-fold (0.18 log units) below what was measured; the range from low to high includes it.
By their numbers in this assay, from the lowest: compounds 2, 1 and 3 (each within the scatter of the next).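

In this assay, pyrrolidin-1-yl in place of 4-ethylpiperazin-1-yl on the carbonyl carbon gives a 1.6-fold higher number from compound 2 to compound 3 (0.19 log units; within the scatter), and pyrrolidin-1-yl in place of (4-chlorobenzyl)amino gives a 1.5-fold higher number from compound 1 to compound 3 (0.17 log units; within the scatter). A second pair of groups on this carbonyl carbon thus stays within the scatter, and all three groups now shown lie within the scatter of one another, although the five-membered ring with 1 hetero atom has 5 heavy atoms and the six-membered ring with 2 hetero atoms has 8. Nothing measured here gives a reason for these values.

On these data alone, it remains open whether another group on this carbonyl carbon, such as morpholin-4-yl or a chain ending in a carboxylic acid, would give a step beyond the scatter. As far as these compounds go, the shared core is the same in all three compounds, so the part played by its hydroxy and methoxy groups also remains open.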